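Polybrominated Cyclopentenone Analogues in a Leukaemia Cell Line

The source may hold more compounds than are shown below. What is called first, only, known or untested is meant among the compounds shown, and "the series" means these compounds.

Measured compounds and their values in a functional assay on K562 cells (Homo sapiens) for cytotoxicity, read by sulforhodamine B assay, with a stated time of 72 h; a higher number here means a weaker inhibitor, a lower number a stronger inhibitor:
Compound 1 `COC(=O)C1=C(c2cc(Br)c(O)c(Br)c2)[C@](OC)(c2ccc(O)c(Br)c2)O[C@@]1(C(=O)OC)c1cc(Br)c(O)c(Br)c1` gives > 10000 nM, which is a limit of the assay.
Compound 2 `O=C1C=C(c2cc(Br)c(O)c(Br)c2)C(=O)C1(c1cc(Br)c(O)c(Br)c1)c1cc(Br)c(O)c(Br)c1` gives > 10000 nM, which is a limit of the assay.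
Compound 3 `COC(=O)C1=C(c2ccc(O)c(Br)c2)C(=O)[C@](c2ccc(O)c(Br)c2)(c2cc(Br)c(O)c(Br)c2)C1=O` gives > 10000 nM, which is a limit of the assay.

Compound 2 therefore stands where every value in this set stands, at the limit of > 10000 nM in this assay, at which 3 of the 3 values shown sit, so no number separates it from compound 1 or compound 3. Compound 4 `COC(=O)C1=C(c2cc(Br)c(O)c(Br)c2)C(=O)C(c2cc(Br)c(O)c(Br)c2)(c2cc(Br)c(O)c(Br)c2)C1=O` differs from compound 2 by methoxycarbonyl in place of hydrogen on a double-bonded ring carbon. Among the measured compounds shown here, no measured step between two neighbouring compounds exists here to size such a change. With all three values sitting at the limit, compound 4 is expected to show a step that the limit leaves unreadable from compound 2 to compound 4 that stays within the scatter and, most likely, the assay would again report only a limit. Compound 4 is estimated at 12000 nM, between 4000 nM and 40000 nM.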

Compound 4, half-maximal inhibitory concentration: > 10000 nM
Compound 4 gave a limit, no number; the forecaster's own chance of this, stated with the estimate: 75%; the middle value does not contradict the limit.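

Among the compounds shown here, compound 4, like compound 2, gives only a limit, so no step between them can be read: the limit of > 10000 nM in this assay, at which 4 of the 4 values shown sit. The compounds shown leave open which structural change, if any, would bring a measurable value in this assay.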